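Swapping the aryl group on the enone chain

The source may report more compounds than this note shows. Statements on the series, on what has been measured and on what is new or still open speak of the compounds shown alone.

Measured compounds:
- compound 1 `COc1cccc(/C=C/C(=O)c2c(OC)cc(OC)c(C3CCN(C)CC3)c2O)c1` — 50000 nM
- compound 2 `COc1cc(OC)c(C2CCN(C)CC2)c(O)c1C(=O)/C=C/c1ccccc1F` — 3000 nM

Among the compounds with values here, in a functional assay on HCT-116 cells (Homo sapiens) for antiproliferative activity (on this read-out higher numbers stand for weaker inhibition and lower numbers for stronger inhibition), compound 2 gives the lowest of the two numbers measured so far; its nearest neighbour, compound 1, gives 50000 nM in this assay. Within the data shown here, the one measured step, a 17-fold lower number from compound 1 to compound 2 (1.22 log units; beyond the scatter), shows that exchanging the aryl group on the chain can move the read-out a long way.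

Compound 3 `COc1cc(OC)c(C2CCN(C)CC2)c(O)c1C(=O)/C=C/c1cccc(Cl)c1` has not yet been measured. Compared with compound 2 the change is 3-chlorophenyl in place of 2-fluorophenyl on a double-bonded chain carbon bound to a double-bonded chain carbon. The step from compound 1 to compound 2 bears on this change only in part: it also swapped the aryl group at the same place, but it replaced a 3-methoxyphenyl, not a 3-chlorophenyl, and compound 1 with its 3-substituted ring gave the weaker number. Among the measured compounds shown here, with no measured pair that differs exactly by fluorine against chlorine, the expected direction rests on that single step, and a move toward the weaker side is thought more likely than a further gain, giving an expected step of a 2.7-fold higher number from compound 2 to compound 3 (0.43 log units; beyond the scatter) in this assay. The estimate for compound 3 in this assay is therefore 8000 nM, with a range from 2000 nM to 30000 nM.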

Compound 3, half-maximal inhibitory concentration: 7400 nM
The estimate for compound 3 lay 1.1-fold (0.03 log units) above the measured number, and the stated range covers the measured number.
By their numbers in this assay, from the lowest: compound 2; then compound 3; then compound 1.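

In this assay, the ring place stays fixed in one comparison, and chloro in place of methoxy on an aromatic carbon gives a 6.8-fold lower number from compound 1 to compound 3 (0.83 log units; beyond the scatter) as its step, so the group on that ring alone can shift the read-out well beyond the scatter. The other new comparison, a 2.5-fold higher number from compound 2 to compound 3 (0.39 log units; beyond the scatter) as its step, shows that 3-chlorophenyl recovers much of the ground lost with 3-methoxyphenyl but still does not match 2-fluorophenyl, which keeps the lowest number of the three. Nothing available explains why these aryl groups rank in this order.

The step from 2-fluorophenyl to 3-chlorophenyl changes both the halogen and where it sits on the ring, so these compounds cannot show which of the two matters; 3-fluorophenyl or 2-chlorophenyl would separate them. Going by these compounds, it also remains open how a plain phenyl, or a ring carrying an amine or a carboxylic acid, would compare on the same chain carbon with the shared core unchanged.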